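The compounds below may be only part of what the source reports. "The series", "measured", "known", "first", "only" and "open" are said of these compounds alone.

Compound 1 `COc1nc2c(c(=O)n(C)c(=O)n2C)n1CC(=O)Nc1cccc(Cl)c1`: > 200000 nM
Compound 2 `COc1nc2c(c(=O)n(C)c(=O)n2C)n1CC(=O)Nc1ccc(C(C)(C)C)cc1`: > 200000 nM

In an assay on isolated protein for inhibition of high affinity 3',5'-cyclic-AMP phosphodiesterase 7A (Homo sapiens), read by cAMP accumulation, with a stated time of 10 min (a lower number here means a stronger inhibitor, a higher number a weaker inhibitor), compound 1 gives > 200000 nM, which is a limit of the assay and not a number. Compound 2 gives > 200000 nM in this assay, likewise a limit of the assay. Both values sit at the limit of > 200000 nM in this assay, at which 2 of the 2 values shown sit, so compound 2 stands at the edge of what the assay reports. Compound 3 `COc1nc2c(c(=O)n(C)c(=O)n2C)n1CC(=O)Nc1ccc(C(C)C)cc1` differs from compound 2 by hydrogen in place of methyl on a saturated chain carbon bound to an aromatic carbon and two saturated chain carbons. Going by the values given here, no step between measured compounds is available to size this change. The expected step is a number no higher from compound 2 to compound 3 (the limit leaves the size open), none beyond the scatter. Compound 3 is estimated at 200000 nM, in the range 50000 nM to 500000 nM, most likely reported again as a limit.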

Compound 3, half-maximal inhibitory concentration: > 200000 nM
Compound 3 gave a limit, no number; the forecaster's own chance of this, stated with the estimate: 80%; the middle value lies on the limit itself.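

In this assay, going by these compounds alone, compound 3 gives > 200000 nM, again a limit of the assay and not a number, so no step from compound 1 or compound 2 to compound 3 can be read. The compounds shown leave open how strongly any of them inhibits, and whether tert-butyl and isopropyl differ at all.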